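A few compounds are considered here, and "the series" means these few. Any claim that something is new, unique, unknown or untested is made for them only; others in the source may bear on it.

Working notes on the sulfonamide-amide series in a functional assay on HEK293 cells for agonist activity at probable G-protein coupled receptor 27 (Homo sapiens), read by a luciferase reporter and beta-arrestin recruitment, with a stated time of 10 min; on this read-out higher numbers stand for an effect only at larger amounts of compound and lower numbers for an effect already at smaller amounts.

Among the measured compounds shown here, compound 3 `O=C(Nc1ccc(S(=O)(=O)Nc2ccccc2)cc1)c1ccc(Cl)cc1F` gives 3980 nM, the highest of the three numbers so far. Compound 1 `O=C(Nc1ccc(S(=O)(=O)Nc2ccccc2)cc1)c1ccc(Cl)nc1F` gives 2290 nM, and the step of a 1.7-fold higher number from compound 1 to compound 3 (0.24 log units; within the scatter) lies within the scatter. Compound 2 `O=C(Nc1ccc(S(=O)(=O)Nc2ccccc2Cl)cc1)c1ccc(Cl)cc1Cl` gives 1260 nM; it differs from compound 3 in two places, so its number and that of compound 3 are all the two structures show, the gap between them being beyond the scatter.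

Compound 4 `COc1cc(Br)ccc1C(=O)Nc1ccc(S(=O)(=O)Nc2ccccc2)cc1` differs from compound 3 as 4-bromo-2-methoxyphenyl in place of 4-chloro-2-fluorophenyl on a carbonyl carbon. For the measured compounds named here, the only measured step on the carbonyl carbon is the one from compound 1 to compound 3, which stayed within the scatter; no step exchanges a halogen for a methoxy group or a chlorine for a bromine, so nothing measured speaks directly to this change. The expectation is therefore a step of no size beyond the scatter, a 1.1-fold lower number from compound 3 to compound 4 (0.06 log units; within the scatter), with wide uncertainty. Compound 4 is thus estimated at 3500 nM in this assay, within 1100 nM to 11000 nM.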

Compound 4, half-maximal effective concentration: 1020 nM
Beside the measured number, compound 4's estimate is 3.4-fold (0.54 log units) above it; measured number below the stated range.
By their numbers in this assay, from the lowest: compounds 4, 2, 1 and 3 (each within the scatter of the next, the first and the last beyond it).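

Among the compounds shown here, on the carbonyl carbon, 4-bromo-2-methoxyphenyl gives the first steps at this position that clear the scatter in this assay, both in place of 4-chloro-2-fluorophenyl (a 3.9-fold lower number from compound 3 to compound 4 (0.59 log units; beyond the scatter)) and in place of 6-chloro-2-fluoropyridin-3-yl (a 2.2-fold lower number from compound 1 to compound 4 (0.35 log units; beyond the scatter)). For the compounds shown here, the group on the carbonyl carbon can therefore move this read-out, although the one earlier step at this position stayed within the scatter. No measurement on hand accounts for these steps.

Open is which exchange carries the step, methoxy for fluorine or bromine for chlorine, since the compounds shown hold neither exchange alone. Also open, from the compounds shown here alone, is how an amine, a carboxylic acid or a longer chain would read in place of the methoxy group.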